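Benzamido in Place of Methoxy: Expected Antiproliferative Shift

The compounds below may be only part of what the source reports. "The series", "measured", "known", "first", "only" and "open" are said of these compounds alone.

Measured compounds:
compound 1, `COc1cc(/C=C/C(C)=O)ccc1OCc1cn(-c2ccccc2CO)nn1`, 65800 nM
compound 2, `COc1cc(/C=C/C(C)=O)ccc1OCc1cn(-c2ccc(/N=N/c3ccccc3)cc2)nn1`, 75900 nM
compound 3, `COc1ccc(-n2cc(COc3ccc(/C=C/C(C)=O)cc3OC)nn2)cc1`, 33700 nM

In a functional assay on MCF7 cells (Homo sapiens) for antiproliferative activity, read by MTT assay, with a stated time of 48 h (on this read-out higher numbers stand for weaker inhibition and lower numbers for stronger inhibition), compound 3 gives the lowest of the three numbers. Its separation from compound 1 is a 2.0-fold lower number from compound 1 to compound 3 (0.29 log units; within the scatter), so those two cannot be ordered, whereas the step of a 2.3-fold lower number from compound 2 to compound 3 (0.35 log units; beyond the scatter) is beyond the scatter and modest in size.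

Compound 4, `COc1cc(/C=C/C(C)=O)ccc1OCc1cn(-c2ccc(NC(=O)c3ccccc3)cc2)nn1`, differs from compound 3 by benzamido in place of methoxy on an aromatic carbon. The step that bears on this change most directly is a 2.3-fold lower number from compound 2 to compound 3 (0.35 log units; beyond the scatter), in which a larger aromatic-ring-bearing group at the same position was exchanged for methoxy and the number fell modestly. Compound 4 reverses that direction of change, putting a larger ring-bearing group back in place of methoxy. The step of a 2.0-fold lower number from compound 1 to compound 3 (0.29 log units; within the scatter) at the same position was within the scatter and so gives no further guidance. A modest rise in this assay is therefore expected, a 1.8-fold higher number from compound 3 to compound 4 (0.25 log units; within the scatter). Compound 4 is estimated at 60000 nM, with a range from 25000 nM to 150000 nM.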

Compound 4, half-maximal inhibitory concentration: 86700 nM
For compound 4 the middle estimate is 1.4-fold (0.16 log units) below the measured one, and the stated range covers the measured number.
By their numbers in this assay, from the lowest: compounds 3, 1, 2 and 4 (each within the scatter of the next, the first and the last beyond it).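

In this assay the exchange of methoxy for benzamido, on the aromatic carbon para to a large group, gives a 2.6-fold higher number from compound 3 to compound 4 (0.41 log units; beyond the scatter) and so shows directly that this second ring-bearing group also stands apart from methoxy. The two ring-bearing groups themselves cannot be ordered, with a 1.1-fold higher number from compound 2 to compound 4 (0.06 log units; within the scatter) in this assay, so replacing the group of compound 2 with benzamido, which brings in an amide hydrogen and a carbonyl, makes no readable difference here. No measurement among the data explains why methoxy and these two groups differ.

Going by these compounds, what remains open is whether a small amine or a carboxylic acid at this place would read like methoxy or like the ring-bearing groups. A longer alkoxy chain would likewise be needed to show whether the number follows group size at all.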